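Naphthalen-1-yl in place of phenyl on compound 2

The compounds below may be only part of what the source reports. "The series", "measured", "known", "first", "only" and "open" are said of these compounds alone.

Going by the values given here, in a functional assay on CAL-27 cells (Homo sapiens) for cytotoxicity, read by MTT assay, with a stated time of 72 h (on this read-out lower numbers stand for stronger inhibition and higher numbers for weaker inhibition), compound 1 `CC(C)(C)NC(=O)CN(CCCCCC(=O)NO)C(=O)c1ccccc1` gives 16700 nM and compound 2 `O=C(CCCCCN(CC(=O)NC1CCCCC1)C(=O)c1ccccc1)NO` gives 3800 nM, the lower of the two numbers so far. Compound 3 `O=C(CCCCCN(CC(=O)NC1CCCCC1)C(=O)c1cccc2ccccc12)NO` keeps the cyclohexyl of compound 2 and differs from it in one place: naphthalen-1-yl in place of phenyl on a carbonyl carbon. Among the compounds with values here, no measured step touches that place. Within the data shown here, the only step available, a 4.4-fold lower number from compound 1 to compound 2 (0.64 log units; beyond the scatter), came with cyclohexyl in place of tert-butyl on an amide-type nitrogen, so it serves only as a loose guide to size. On that guide, a modest step to a lower number is expected in this assay, although a result within the scatter would not be surprising. The estimated change is a 2.1-fold lower number from compound 2 to compound 3 (0.32 log units; beyond the scatter). Compound 3 is expected at 1800 nM, within an estimated range of 600 nM to 5500 nM.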

Compound 3, half-maximal inhibitory concentration: 2400 nM
Compound 3: middle estimate off by 1.3-fold (0.12 log units), on the low side; the measured number falls inside the stated range.
By their numbers in this assay, from the lowest: compounds 3 and 2 (each within the scatter of the next); then compound 1.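

In this assay, naphthalen-1-yl in place of phenyl on a carbonyl carbon gives a 1.6-fold lower number from compound 2 to compound 3 (0.20 log units; within the scatter), so this is a step that stays within the scatter. Going by these compounds alone, the position therefore takes a group of 10 heavy atoms in place of 6, with a second aromatic ring, without any change that can be told from repeat-measurement noise, unlike the one earlier step at the amide-type nitrogen, a 4.4-fold lower number from compound 1 to compound 2 (0.64 log units; beyond the scatter). Nothing measured here explains this result.

From the compounds shown here alone, both groups at this place are aromatic rings of carbon only, so it remains open how a pyridine ring, or a phenyl ring carrying an amine, would read there. Also open, going by these compounds, is whether naphthalen-1-yl would give the same small step alongside the tert-butyl of compound 1.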